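Chain length and cell growth inhibition in a pyrrolopyrimidine series

The source may hold more compounds than are shown below. What is called first, only, known or untested is meant among the compounds shown, and "the series" means these compounds.

Measured so far:
Compound 1 `CN(C)C(=O)c1cc2cnc(Nc3ccc(S(=O)(=O)NCCCCCN=C=S)cc3)nc2n1C1CCCC1` gives 83.4%.
Compound 2 `CN(C)C(=O)c1cc2cnc(Nc3ccc(S(=O)(=O)NCCCCCCN=C=S)cc3)nc2n1C1CCCC1` gives 70.6%.
Compound 3 `CN(C)C(=O)c1cc2cnc(Nc3ccc(C(=O)NCCCCN=C=S)cc3O)nc2n1C1CCCC1` gives 51.8%.

All three were tested in a functional assay on NCI-H1299 cells (Homo sapiens) for inhibition, read by CCK-8 assay, with a stated time of 72 h, tested at 10 uM; on this read-out lower numbers stand for a weaker effect and higher numbers for a stronger effect at the one concentration tested. Compound 1 and compound 2 differ by a group of 4 heavy atoms (2 carbon, 1 nitrogen, 1 sulfur; no ring) in place of a group of 3 heavy atoms (1 carbon, 1 nitrogen, 1 sulfur; no ring), on a saturated chain carbon, five bonds along the chain from a sulfonamide nitrogen, and that change made a step of a number 12.8 percentage points lower from compound 1 to compound 2 (beyond the scatter). Compound 3 carries a different core; how its core differs from that of compound 1 is not broken down here. Compound 3 stands lowest of the three measured compounds.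

Compound 4 `CN(C)C(=O)c1cc2cnc(Nc3ccc(C(=O)NCCCCCN=C=S)cc3O)nc2n1C1CCCC1` is not yet measured. It differs from compound 3 by a group of 4 heavy atoms (2 carbon, 1 nitrogen, 1 sulfur; no ring) in place of a group of 3 heavy atoms (1 carbon, 1 nitrogen, 1 sulfur; no ring), on a saturated chain carbon, four bonds along the chain from an amide-type nitrogen. Among the compounds with values here, this is the same kind of change as the one from compound 1 to compound 2, though not the same: there the place was five bonds along the chain from a sulfonamide nitrogen, here it is four bonds along the chain from an amide-type nitrogen. Resting on the step of a number 12.8 percentage points lower from compound 1 to compound 2 (beyond the scatter), a step of similar size is expected from compound 3 to compound 4, namely a number 11.8 percentage points lower from compound 3 to compound 4 (beyond the scatter). Compound 4 is therefore estimated at 40% in this assay, most likely between 26% and 54%.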

Compound 4, a percentage reported as inhibition, at one concentration (the size of the read-out at that concentration, not a potency): 80.7%
The estimate for compound 4 lay 40.7 percentage points below the measured number; measured number above the stated range.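

In this assay the same change gave a number 28.9 percentage points higher from compound 3 to compound 4 (beyond the scatter), a step opposite in direction to the one seen on the core of compound 1. The two steps disagree: the same change on two cores in this assay, a number 12.8 percentage points lower (beyond the scatter) from compound 1 to compound 2 and a number 28.9 percentage points higher (beyond the scatter) from compound 3 to compound 4, 41.7 percentage points apart, beyond the scatter of two such steps Within this series, then, the effect of this change cannot be carried from one core to the other, but the data do not show which feature of the cores lies behind the disagreement, and each step rests on a single pair of compounds.

The compounds shown leave open whether a longer chain on the core of compound 3 would extend the rise or reverse it. They also leave open how an amine at the end of the chain would compare on either core.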